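A few compounds are considered here, and "the series" means these few. Any claim that something is new, unique, unknown or untested is made for them only; others in the source may bear on it.

Compound 1 `CNC(=O)c1cc(C(=O)N[C@H]2CC[C@H](O)CC2)c([C@@H](C)c2cccc(F)c2)o1` is the starting point, and the measurement followed here is a physicochemical assay for solubility, measured as kinetic solubility; a higher number here means a more soluble compound, a lower number a less soluble compound. In this test compound 1 gives >= 63 ug/mL, which is a limit of the assay and not an exact number. Going by the values given here, compound 2 `CNC(=O)c1cc(C(=O)N[C@H]2[C@@H]3C[C@H](O)C[C@@H]32)n([C@@H](C)c2cccc(Cl)c2)n1` is the only other compound measured so far, and compound 2 gives >= 168 ug/mL, which is also a limit. Among the compounds with values here, no pair of measured compounds differs in just one place, so the data hold no direct measure of the change considered next.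

Compound 3 `CNC(=O)c1cc(C(=O)N[C@H]2CC[C@H](O)CC2)c([C@@H](C)c2cccc(C)c2)o1` keeps the rest of compound 1 and has methyl in place of fluoro on an aromatic carbon, meta to a large group (methyl in place of fluoro on an aromatic carbon), turning 3-fluorophenyl into 3-methylphenyl. No shift beyond the usual scatter is expected in this assay, in either direction. The only anchor for this expectation is compound 1, with its limit of >= 63 ug/mL. In numbers, the expected step is an at least 1.0-fold lower number from compound 1 to compound 3 (0.02 log units; that floor lies within the scatter). The assay may again report only a limit. For compound 3 the estimated solubility is 60 ug/mL, with an expected range of 25 ug/mL to 150 ug/mL.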

Compound 3, solubility: >= 172 ug/mL
Compound 3: only a limit was reported; the forecaster's own chance of this, stated with the estimate: 50%; middle value at least 2.8-fold (0.45 log units) from the limit.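

In this assay, compound 1 and compound 3 each carry only a limit of the assay and not an exact number, and no step can be read between them. Still open, going by these compounds, are the exact numbers for these two compounds and whether methyl in place of fluoro on the aromatic carbon shifts the result at all.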